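A few compounds are considered here, and "the series" means these few. Any claim that something is new, unique, unknown or untested is made for them only; others in the source may bear on it.

Of the compounds shown here, two have so far been measured in a functional assay on A549 cells (Homo sapiens) for cytotoxicity, read by MTT assay, with a stated time of 72 h; a lower number here means a stronger inhibitor, a higher number a weaker inhibitor. Compound 1 `O=C(Nc1nc2ccccc2s1)c1cn(-c2ccccc2)nc1-c1ccccc1` gives 13500 nM. Compound 2 `Cc1ccc2nc(NC(=O)c3cn(-c4ccccc4)nc3-c3ccccc3)sc2c1`, which carries a methyl in place of hydrogen on an aromatic carbon, gives 26500 nM. Going by the values given here, the only step measured is a 2.0-fold higher number from compound 1 to compound 2 (0.29 log units; within the scatter). Compound 2 thus sits at one end of these two numbers, separated from compound 1 only by a gap within the scatter. Compound 3 `COc1ccc(-c2nn(-c3ccccc3)cc2C(=O)Nc2nc3ccc(C)cc3s2)cc1` has not yet been measured. It differs from compound 2 by methoxy in place of hydrogen on an aromatic carbon, para to a large group, so that phenyl becomes 4-methoxyphenyl. Among the compounds with values here, no measured step involves a methoxy. Within the data shown here, the one step at hand, a 2.0-fold higher number from compound 1 to compound 2 (0.29 log units; within the scatter), concerns a different ring and stayed within the scatter. With so little to go on, compound 3 is expected to show a 1.1-fold lower number from compound 2 to compound 3 (0.03 log units; within the scatter), nothing beyond the scatter. Compound 3 is therefore estimated at 25000 nM, with a range from 8000 nM to 80000 nM.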

Compound 3, half-maximal inhibitory concentration: 27700 nM
Beside the measured number, compound 3's estimate is 1.1-fold (0.04 log units) below it, within the range that was stated.
By their numbers in this assay, from the lowest: compounds 1, 2 and 3 (each within the scatter of the next, the first and the last beyond it).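

Going by these compounds alone, the first change on this phenyl ring, turning it into 4-methoxyphenyl, gives a 1.0-fold higher number from compound 2 to compound 3 (0.02 log units; within the scatter) in this assay. Within the data shown here, the earlier step concerned a different ring, so this is the first sign that a methoxy group, para to a large group, can be added to this ring with no difference beyond the scatter in this cell-killing read-out. Nothing measured on these compounds offers an explanation for this result.

From the compounds shown here alone, a single group at a single position says little about the position as a whole, so it remains open whether an amine, a carboxylic acid or a chlorine atom in the same place would also stay within the scatter. Also open, going by these compounds, is whether any change to this ring can bring the number clearly lower than that of compound 2.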